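Methyl on the N-aryl ring of the benzimidazolyl sulfonamides

The source may report more compounds than this note shows. Statements on the series, on what has been measured and on what is new or still open speak of the compounds shown alone.

Measured so far:
compound 1, `COc1cc(N(Cc2nc3ccccc3[nH]2)S(=O)(=O)c2ccc(C)cc2)cc(OC)c1OC`: 5400 nM
compound 2, `COc1cc(N(Cc2nc3ccccc3[nH]2)S(=O)(=O)c2ccccc2)cc(OC)c1OC`: 27300 nM
compound 3, `Cc1ccc(S(=O)(=O)N(Cc2nc3ccccc3[nH]2)c2ccccc2)cc1`: 49700 nM

All three were read in a functional assay on MCF7 cells (Homo sapiens) for inhibition, read by MTT assay, with a stated time of 48 h; on this read-out lower numbers stand for stronger inhibition and higher numbers for weaker inhibition. Among the measured compounds shown here, compound 1 gives 5400 nM and compound 2 gives 27300 nM; the step of a 5.1-fold lower number from compound 2 to compound 1 (0.70 log units; beyond the scatter) is the only single-point change measured here, and the change is methyl in place of hydrogen on an aromatic carbon. Compound 3 gives 49700 nM, the highest number of the three; against compound 2 the gap is within the scatter, against compound 1 it is beyond it. The difference between the core of compound 3 and the core of compound 2 is not broken down here.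

Compound 4, `Cc1ccc(N(Cc2nc3ccccc3[nH]2)S(=O)(=O)c2ccc(C)cc2)cc1`, has not been measured. It differs from compound 3 by methyl in place of hydrogen on an aromatic carbon. This is the same kind of change as that from compound 2 to compound 1: the place reads alike, but for compound 2 to compound 1 the change cut one bond further out also reads phenylsulfonyl to (4-methylphenyl)sulfonyl, which is not so here, the methyl entering on a different ring of the molecule. The expectation for compound 4 rests on a single precedent, a 5.1-fold lower number from compound 2 to compound 1 (0.70 log units; beyond the scatter), made on a different core, so the step of a 3.6-fold lower number from compound 3 to compound 4 (0.55 log units; beyond the scatter) is estimated smaller and with wide bounds. In this assay compound 4 is expected to give about 14000 nM, between 4500 nM and 45000 nM.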

Compound 4, half-maximal inhibitory concentration: > 50000 nM
Compound 4 was reported as a limit (the forecaster's own chance of this, stated with the estimate: 15%); middle value at least 3.5-fold (0.55 log units) away from the limit.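

In this assay compound 4 stands as a limit, > 50000 nM, and the step reads a number no lower from compound 3 to compound 4 (the limit leaves the size open) with a size that cannot be read. Even so, methyl in place of hydrogen on an aromatic carbon did not give the same result on the two cores, and the precedent did not carry across: the same change on two cores in this assay, a 5.1-fold lower number (0.70 log units; beyond the scatter) from compound 2 to compound 1 and a number no lower (the limit leaves the size open) from compound 3 to compound 4, at least 5.0-fold (0.70 log units) apart, beyond the scatter of two such steps

This does not show that the core alone decides the outcome. The methyl enters a different ring in compound 4 than in compound 1, so the change of core and the change of ring remain tangled, and one step on each core supports no rule for the series.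

Still open, on these data alone, is how an ethyl group, a longer chain, an amine or a carboxylic acid in place of the methyl on the 4-methylphenyl ring of compound 4 would read on this core. Also open, as far as these compounds go, is whether any of these groups would follow the same course on the core of compound 1, which would help separate the effect of the core from that of the ring carrying the group.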